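Bromo to Methyl: Predicting an Unmeasured Analogue

This account rests on a few compounds, and the source may have more. Where it says the series, first, only, none or still open, it means among the compounds named here.

Two pairs of compounds share one small change. Compound 1 `O=C1/C(=C/c2ccc(Br)cc2)Cc2ccccc21` and compound 2 `Cc1ccc(/C=C2\Cc3ccccc3C2=O)cc1` share one core, while compound 3 `O=C1CCCCC/C1=C\c1cccc(Br)c1` and compound 4 `Cc1cccc(/C=C2\CCCCCC2=O)c1` share another; the difference between the two cores is not broken down here. In a functional assay on CCRF-CEM cells (Homo sapiens) for inhibition (on this read-out higher numbers stand for weaker inhibition and lower numbers for stronger inhibition), compound 1 gives 284000 nM, and compound 2 gives 67100 nM. The change between them is methyl in place of bromo on an aromatic carbon and it brought a 4.2-fold lower number from compound 1 to compound 2 (0.63 log units; beyond the scatter). Compound 3 gives 137000 nM in this assay, a number that sits between those of compound 1 and compound 2. Compound 4 has not yet been measured. It differs from compound 3 by methyl in place of bromo on an aromatic carbon. This is the same kind of change as from compound 1 to compound 2, not the same: in compound 2 the methyl sits para to a large group, whereas in compound 4 it sits meta to a group of 9 heavy atoms, and the cores differ as well. Among the compounds with values here, with only one measured example of this change, the expectation rests on compound 1 and compound 2, because a 4.2-fold lower number from compound 1 to compound 2 (0.63 log units; beyond the scatter) points toward a lower number. The surroundings are not identical, though. A somewhat smaller step is therefore expected, namely a 3.0-fold lower number from compound 3 to compound 4 (0.48 log units; beyond the scatter). For compound 4 the estimated value in this assay is 45000 nM, with a likely range from 15000 nM to 140000 nM.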

Compound 4, half-maximal inhibitory concentration: 170000 nM
Compound 4: the middle estimate sits 3.8-fold (0.58 log units) below what was measured; measured number above the stated range.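

Replacing bromo with methyl does not repeat its earlier effect in this assay: this time the result is a 1.2-fold higher number from compound 3 to compound 4 (0.09 log units; within the scatter) and so the two compounds cannot be told apart on this read-out. This does not explain the contrast, as the two pairs differ both in their core and in where the new group sits on the aromatic ring, and two pairs cannot separate those differences. What the comparison does show is that a gain seen on one core cannot simply be assumed on the other, and that the two outcomes differ by more than ordinary repeat variation would explain: the same change on two cores in this assay, a 4.2-fold lower number (0.63 log units; beyond the scatter) from compound 1 to compound 2 and a 1.2-fold higher number (0.09 log units; within the scatter) from compound 3 to compound 4, 5.3-fold (0.72 log units) apart, beyond the scatter of two such steps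

The compounds shown carry only bromo or methyl at this place on the ring, so it remains open how a different group, such as an amine, a carboxylic acid or a longer chain, would behave on either core. Also open, going by these compounds, is whether the bromo-to-methyl change would give matching results on the two cores if it were made at the same place on the ring in both.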